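Urea-linked pyrazole series: aryl swap on the urea nitrogen

The compounds below may be only part of what the source reports. "The series", "measured", "known", "first", "only" and "open" are said of these compounds alone.

Measured so far in a functional assay on T47D cells (Homo sapiens) for inhibition, read by sulforhodamine B assay, with a stated time of 48 h; on this read-out lower numbers stand for stronger inhibition of growth and higher numbers for weaker inhibition of growth:
- compound 1 `O=C(Nc1cccc(-n2cc(-c3ccncc3)c(-c3ccc(Cl)c(O)c3)n2)c1)Nc1cccc(C(F)(F)F)c1` gives 2470 nM
- compound 2 `COc1cc(-c2nn(-c3cccc(NC(=O)Nc4ccc(Cl)c(Cl)c4)c3)cc2-c2ccncc2)ccc1Cl` gives 1420 nM
- compound 3 `O=C(Nc1cccc(-n2cc(-c3ccncc3)c(-c3ccc(Cl)c(O)c3)n2)c1)Nc1ccc(Cl)c(Cl)c1` gives 1550 nM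

Compound 4 `COc1cc(-c2nn(-c3cccc(NC(=O)Nc4cccc(C(F)(F)F)c4)c3)cc2-c2ccncc2)ccc1Cl` has not been measured in this assay.

Compound 3 and compound 1 differ by 3-(trifluoromethyl)phenyl in place of 3,4-dichlorophenyl on an amide-type nitrogen, and the step is a 1.6-fold higher number from compound 3 to compound 1 (0.20 log units; within the scatter). The same change, (3-(trifluoromethyl)phenyl in place of 3,4-dichlorophenyl on an amide-type nitrogen), carries compound 2 to compound 4; the place is identical in both pairs, so this is the same change made on a second core. The two cores differ by methyl in place of hydrogen on an oxygen on an aromatic ring, and that difference gave a 1.1-fold higher number from compound 2 to compound 3 (0.04 log units; within the scatter).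

Given that the change from compound 3 to compound 1 stayed within the scatter, compound 4 is expected to sit close to compound 2, with a step of about a 1.6-fold higher number from compound 2 to compound 4 (0.21 log units; within the scatter) in this assay. Compound 4 is estimated at 2300 nM, within 1100 nM to 4800 nM.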

Compound 4, concentration for 50% growth inhibition: 1650 nM
For compound 4 the middle estimate is 1.4-fold (0.14 log units) above the measured one; the measured number falls inside the stated range.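

In this assay, 3-(trifluoromethyl)phenyl in place of 3,4-dichlorophenyl on an amide-type nitrogen gives a 1.2-fold higher number from compound 2 to compound 4 (0.07 log units; within the scatter), and the two cores do not separate on this change: the same change on two cores in this assay, a 1.6-fold higher number (0.20 log units; within the scatter) from compound 3 to compound 1 and a 1.2-fold higher number (0.07 log units; within the scatter) from compound 2 to compound 4, 1.4-fold (0.14 log units) apart, within the scatter of two such steps

Methyl in place of hydrogen on the oxygen gives a 1.5-fold lower number from compound 1 to compound 4 (0.18 log units; within the scatter), and this change also reads alike on both cores: the same change on two cores in this assay, a 1.1-fold higher number (0.04 log units; within the scatter) from compound 2 to compound 3 and a 1.5-fold higher number (0.18 log units; within the scatter) from compound 4 to compound 1, 1.4-fold (0.14 log units) apart, within the scatter of two such steps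

All these steps lie within the scatter, so the four compounds show that neither change moved the number on either core, but not that a step of real size would carry from one core to the other.

Still open, on these data alone, is whether an amine or a carboxylic acid in place of the aryl group on the amide-type nitrogen would give a step beyond the scatter. The same question stands for a longer chain in place of methyl on the oxygen.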